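The source may hold more compounds than are shown below. What is called first, only, known or untested is meant among the compounds shown, and "the series" means these compounds.

Measured compounds:

- Compound 1 `c1ccc(CNCc2cn(Cc3ccccc3)c3ccccc23)cc1` — 362000 nM
- Compound 2 `C#CCN(Cc1ccccc1)Cc1cc2ccccc2n1C` — 60000 nM

In an assay on isolated protein for inhibition of Amine oxidase [flavin-containing] B (Rattus norvegicus) (a higher number here means a weaker inhibitor, a lower number a stronger inhibitor), compound 1 gives 362000 nM, the highest of the two numbers recorded, so it is the weaker of the pair. In this assay compound 2 gives 60000 nM, a lower number that lies beyond the usual scatter. For the measured compounds named here, the two share no single-point difference, so their values say only that compound 2 binds more tightly.

Compound 3 `CCNCc1cn(Cc2ccccc2)c2ccccc12` has not yet been measured. It differs from compound 1 in one place: methyl in place of phenyl on a saturated chain carbon bound to an amine nitrogen. Going by the values given here, no step of this kind between measured compounds is known, so the size of the change can only be guessed. A modest shift in this assay is expected, with no strong ground for either direction beyond the scatter. Compound 3 is therefore expected to give 300000 nM, with a range from 60000 nM to 1500000 nM, which corresponds to an expected step of a 1.2-fold lower number from compound 1 to compound 3 (0.08 log units; within the scatter).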

Compound 3, inhibition constant: 429000 nM
Beside the measured number, compound 3's estimate is 1.4-fold (0.16 log units) below it; measured number inside the range.
By their numbers in this assay, from the lowest: compound 2; then compounds 1 and 3 (each within the scatter of the next).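

In this assay, putting methyl in place of phenyl on a saturated chain carbon bound to an amine nitrogen gives a 1.2-fold higher number from compound 1 to compound 3 (0.07 log units; within the scatter). For the compounds shown here, this is the first step that can be read at this position, and it shows that benzylamino and ethylamino cannot be told apart in this assay, even though the change removes a whole six-membered aromatic ring. Nothing available offers a reason for this result.

On these data alone, whether a longer chain such as butyl, a saturated ring such as cyclohexyl, or a carboxylic acid in the same place would move the number beyond the scatter remains open. Also open, as far as these compounds go, is whether any group at this position can bring the number down at all.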